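The compounds below may be only part of what the source reports. "The series", "measured", "known", "first", "only" and "open" are said of these compounds alone.

In a toxicity assay on HepG2 cells (Homo sapiens) for inhibition, read by CellTiter-Glo, with a stated time of 48 h (a lower number here means a stronger inhibitor, a higher number a weaker inhibitor), compound 1 `COc1ccc2nc(C)cc(OCC(=O)Nc3ccc(Cl)cc3)c2c1` reaches only a limit of the assay, > 100000 nM. Among the compounds with values here, compound 2 `COc1ccc2nc(C)cc(OCC(=O)Nc3c(C)cncc3C)c2c1` gives 12600 nM, the only number reported for this assay; the other value sits at the limit of > 100000 nM in this assay, at which 1 of the 2 values shown sits. Within the data shown here, the one measured step, an at least 7.9-fold lower number from compound 1 to compound 2 (0.89 log units; beyond the scatter), also changed the group on the amide-type nitrogen, exchanging 4-chlorophenyl for 3,5-dimethylpyridin-4-yl. Compound 3 `COc1ccc2nc(C)cc(OCC(=O)Nc3noc(C)c3C)c2c1` differs from compound 2 by 4,5-dimethyl-1,2-oxazol-3-yl in place of 3,5-dimethylpyridin-4-yl on an amide-type nitrogen. Among the measured compounds shown here, the measured step bears on this change only loosely: it shows that the group on the amide-type nitrogen can move the number in this assay by a modest amount, but no measured pair compares a six-membered aromatic ring with a five-membered one. The account therefore expects a step of a 1.6-fold higher number from compound 2 to compound 3 (0.20 log units; within the scatter) in this assay, within the scatter or slightly weaker. Compound 3 is estimated at 20000 nM, with a likely range from 5000 nM to 100000 nM.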

Compound 3, half-maximal inhibitory concentration: > 100000 nM
Compound 3 was reported as a limit; the forecaster's own chance of this, stated with the estimate: 35%; middle value at least 5.0-fold (0.69 log units) from the limit.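

Among the groups shown on the amide-type nitrogen, only 3,5-dimethylpyridin-4-yl gives a number in this assay, and putting 4,5-dimethyl-1,2-oxazol-3-yl in its place gives an at least 7.9-fold higher number from compound 2 to compound 3 (0.89 log units; beyond the scatter). The earlier lowering therefore does not follow from simply leaving 4-chlorophenyl: with a five-membered aromatic ring carrying two hetero atoms in this place, the value returns to the limit of the assay. Compound 1 and compound 3 both sit at that limit, and the step between them cannot be read: the limit of > 100000 nM in this assay, at which 2 of the 3 values shown sit.

The compounds shown leave open whether the number follows the ring size or the hetero atoms, a question that a 2,6-dimethylphenyl group on the same nitrogen would bear on. Also open, going by these compounds, is where a plain pyridin-4-yl group, without the two methyl groups, would fall in this assay.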